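This account rests on a few compounds, and the source may have more. Where it says the series, first, only, none or still open, it means among the compounds named here.

Working notes on the series. All readings come from an ADME assay on HeLa cells (Homo sapiens) for cytotoxicity, read by ATP content, with a stated time of 3 days; a higher number here means that more compound is tolerated, a lower number that less compound is tolerated. Compound 1 `N=C(CCCn1c(Cn2c(=O)n(C3CC3)c3ccncc32)cc2cc(Cl)ccc21)NO` gives only a limit there, > 50000 nM. Compound 2 `O=c1n(Cc2cc3cc(Br)ccc3n2CCCCO)c2cnccc2n1C1CC1` likewise gives a limit, > 50000 nM. Compound 3 `N#CCCCn1c(Cn2c(=O)n(-c3ccncc3F)c3ccncc32)cc2cc(Cl)ccc21` also returns a limit, > 50000 nM. Compound 3 thus stands together with the other two at the limit of > 50000 nM in this assay, at which 3 of the 3 values shown sit, and no numerical value exists among the three. Compound 4 `N#CCCCn1c(Cn2c(=O)n(-c3ccncn3)c3ccncc32)cc2cc(Cl)ccc21` carries pyrimidin-4-yl in place of 3-fluoropyridin-4-yl on an aromatic nitrogen. For the measured compounds named here, no measured pair that differs in one place is known, so nothing sets the size of this step; the expectation is no change in this assay beyond the scatter, a step that the limit leaves unreadable from compound 3 to compound 4, with compound 4 most likely again reported only as a limit. Compound 4 is estimated at 60000 nM, within 30000 nM to 150000 nM.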

Compound 4, half-maximal cytotoxic concentration: > 50000 nM
Compound 4: no number, only a limit; the forecaster's own chance of this, stated with the estimate: 85%; the middle value does not contradict the limit.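

Compound 3 and compound 4 each give only a limit, and the step between them, pyrimidin-4-yl in place of 3-fluoropyridin-4-yl, cannot be read. The compounds shown leave open how far any of them differs from the others in tolerated concentration, as all sit at one value: the limit of > 50000 nM in this assay, at which 4 of the 4 values shown sit.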